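The compounds below may be only part of what the source reports. "The series", "measured", "known", "first", "only" and "open" are said of these compounds alone.

Measured compounds in this series:

compound 1 `Nc1nc(N)c2c(-c3ccsc3)cn([C@@H]3O[C@H](CO)[C@@H](O)[C@H]3O)c2n1` — > 100000 nM
compound 2 `Cc1ncnc2c1c(-c1cccs1)cn2[C@@H]1O[C@H](CO)[C@@H](O)[C@H]1O` — > 20000 nM
compound 3 `Nc1nc(N)c2c(-c3ccoc3)cn([C@@H]3O[C@H](CO)[C@@H](O)[C@H]3O)c2n1` — > 20000 nM

In a functional assay on A549 cells (Homo sapiens), read by MTT assay, with a stated time of 72 h (a lower number here means a stronger inhibitor, a higher number a weaker inhibitor), compound 1 gives > 100000 nM, which is a limit of the assay and not a number. Compound 2 gives > 20000 nM, likewise a limit. Compound 3 gives > 20000 nM, again a limit. Compound 1 therefore stands only at a limit, and the two other values shown are limits as well: the limit of > 100000 nM in this assay, at which 1 of the 3 values shown sits, and the limit of > 20000 nM in this assay, at which 2 of the 3 values shown sit, account for all three.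

Within the data shown here, the single one-place step among the measured compounds is a step that the two limits leave unreadable from compound 1 to compound 3; its size cannot be read because the limit of > 100000 nM in this assay, at which 1 of the 3 values shown sits, and the limit of > 20000 nM in this assay, at which 2 of the 3 values shown sit, bracket both ends.

Compound 4 `Cc1nc(N)c2c(-c3ccsc3)cn([C@@H]3O[C@H](CO)[C@@H](O)[C@H]3O)c2n1` differs from compound 1 as follows: methyl in place of amino on an aromatic carbon. No measured step touches this change, so no direction or size can be drawn from the numbers shown. Compound 4 is expected to give 60000 nM, with a range from 10000 nM to 300000 nM. The step expected is an at least 1.6-fold lower number from compound 1 to compound 4 (0.22 log units; that floor lies within the scatter), most likely again reported only as a limit.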

Compound 4, half-maximal inhibitory concentration: > 20000 nM
Compound 4 gave a limit, no number; the forecaster's own chance of this, stated with the estimate: 85%; the middle value does not contradict the limit.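

In this assay compound 4 gives > 20000 nM, a limit of the assay and not a number, so the step from compound 1 to compound 4 cannot be read. The compounds shown leave open whether any change on the shared core yields an actual number in this assay rather than a limit.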